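Ether Substituent Swap on a Shared Core

The source may hold more compounds than are shown below. What is called first, only, known or untested is meant among the compounds shown, and "the series" means these compounds.

Two compounds have been measured in an assay on cells with melanin-concentrating hormone receptor 1 (Homo sapiens) as the target, read by radioligand binding; on this read-out lower numbers stand for stronger inhibition and higher numbers for weaker inhibition:
compound 1 `Nc1ccc2cccc(OC3CCCC3)c2n1`: > 2000 nM, a limit of the assay.
compound 2 `CSCCOc1cccc2ccc(N)nc12`: > 2000 nM, also a limit of the assay.

Compound 2 thus stands at the limit of > 2000 nM in this assay, at which 2 of the 2 values shown sit, together with compound 1, so the step that the two limits leave unreadable from compound 1 to compound 2 cannot be read. Compound 3 `CCCC(C)Oc1cccc2ccc(N)nc12` differs from compound 2 by 1-methylbutyl in place of 2-(methylsulfanyl)ethyl on an oxygen on an aromatic ring. Among the compounds with values here, the only measured step also exchanges the group on the ring oxygen and yields no readable size, so no direction beyond the scatter can be expected, and a further limit appears most likely. Compound 3 is therefore estimated at 5000 nM, between 1500 nM and 30000 nM, which means an expected step that the limit leaves unreadable from compound 2 to compound 3.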

Compound 3, half-maximal inhibitory concentration: 105 nM
Estimate against measurement, compound 3: 48-fold (1.68 log units) above; measured number outside the range, below it.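

In this assay, the group on the ring oxygen proves able to change the result strongly: 1-methylbutyl gives an at least 19-fold lower number from compound 2 to compound 3 (1.27 log units; beyond the scatter), and an at least 19-fold lower number from compound 1 to compound 3 (1.27 log units; beyond the scatter). This position therefore does not accept all ether groups alike, as 1-methylbutyl gives a measured number where cyclopentyl and 2-(methylsulfanyl)ethyl give only limits. The full size of both steps stays unknown because compounds 1 and 2 sit at a limit: the limit of > 2000 nM in this assay, at which 2 of the 3 values shown sit.

The compounds shown do not tell whether the branch in 1-methylbutyl matters. From the compounds shown here alone, how a straight pentyl chain or a chain ending in an amine would read on this oxygen remains open.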